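Bromo in place of hydroxy on the aryl ring

A few compounds are considered here, and "the series" means these few. Any claim that something is new, unique, unknown or untested is made for them only; others in the source may bear on it.

Three compounds share one core. Compound 1 `CC1(C)[C@H]2CC[C@]1(C)N(Cc1cn(-c3ccc(Cl)cc3)nn1)C(=O)C2` gives 410 nM in a functional assay on SGC-7901 cells (Homo sapiens) for inhibition, read by MTT assay, with a stated time of 24 h; a higher number here means a weaker inhibitor, a lower number a stronger inhibitor. Compound 2 `COc1ccc(-n2cc(CN3C(=O)C[C@@H]4CC[C@@]3(C)C4(C)C)nn2)cc1` gives 480 nM, and compound 3 `CC1(C)[C@H]2CC[C@]1(C)N(Cc1cn(-c3cccc(O)c3)nn1)C(=O)C2` gives 270 nM. The steps of a 1.5-fold lower number from compound 1 to compound 3 (0.18 log units; within the scatter) and a 1.8-fold lower number from compound 2 to compound 3 (0.25 log units; within the scatter) both stay within the scatter, as does a 1.2-fold higher number from compound 1 to compound 2 (0.07 log units; within the scatter), so the three compounds are not separated by these numbers.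

Compound 4 `CC1(C)[C@H]2CC[C@]1(C)N(Cc1cn(-c3cccc(Br)c3)nn1)C(=O)C2` differs from compound 3 by bromo in place of hydroxy on an aromatic carbon. Every change so far on this aryl ring, whether of group or of position, has left the read-out within the scatter, so no step beyond the scatter is expected here either. For compound 4 a value of 380 nM is estimated, between 190 nM and 760 nM, which means an expected step of a 1.4-fold higher number from compound 3 to compound 4 (0.15 log units; within the scatter).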

Compound 4, half-maximal inhibitory concentration: 120 nM
Compound 4: the middle estimate sits 3.2-fold (0.50 log units) above what was measured, outside the stated range (below it).
By their numbers in this assay, from the lowest: compound 4; then compounds 3, 1 and 2 (each within the scatter of the next).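

The aryl ring now gives steps beyond the scatter: bromo in place of hydroxy gives a 2.3-fold lower number from compound 3 to compound 4 (0.35 log units; beyond the scatter) and 3-bromophenyl gives both a 3.4-fold lower number from compound 1 to compound 4 (0.53 log units; beyond the scatter) and a 4.0-fold lower number from compound 2 to compound 4 (0.60 log units; beyond the scatter) as its steps from the two other aryl groups. The read-out at this ring carbon therefore depends on the group it carries, though all three steps remain modest. No measurement bears on what lies behind this change.

On these data alone, compounds 1 and 4 differ in both group and position, so the share of each remains open. An amine or a carboxylic acid on the same ring carbon would show how far the read-out moves beyond bromo.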